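This account rests on a few compounds, and the source may have more. Where it says the series, first, only, none or still open, it means among the compounds named here.

Working notes on a small set of compounds tested in a functional assay on B16 cells (Mus musculus) for cytotoxicity, read by MTT assay, with a stated time of 3 days; a higher number here means a weaker inhibitor, a lower number a stronger inhibitor. Compound 1 `COc1ccc(/C=C/C(=O)c2ccc(OC)c([N+](=O)[O-])c2)cc1OC` carries a nitro group. In this assay compound 1 gives > 100000 nM, which is a limit of the assay and not a number. Compound 2 `COc1ccc(C(=O)/C=C/c2ccc(OC)c(OC)c2)cc1N` differs from compound 1 by amino in place of nitro on an aromatic carbon, and in this assay compound 2 gives 18000 nM. The step is an at least 5.5-fold lower number from compound 1 to compound 2 (0.74 log units; beyond the scatter), with the nitro end of it resting on (the limit of > 100000 nM in this assay, at which 2 of the 3 values shown sit).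

Compound 3 `COc1ccc(/C=C/C(=O)c2cc(OC)c(OC)c(OC)c2)cc1[N+](=O)[O-]` again carries a nitro group, on a different core; the difference between the core of compound 1 and the core of compound 3 is not broken down here. In this assay compound 3 gives > 100000 nM, a limit of the assay rather than a number.

Compound 4 `COc1ccc(/C=C/C(=O)c2cc(OC)c(OC)c(OC)c2)cc1N` is not yet measured. Going by the values given here, it differs from compound 3 by amino in place of nitro on an aromatic carbon, the same change as the one from compound 1 to compound 2, the surroundings of the place reading the same in both cases.

For compound 4 a step of an at least 5.0-fold lower number from compound 3 to compound 4 (0.69 log units; beyond the scatter) is expected in this assay. That expectation rests on an at least 5.5-fold lower number from compound 1 to compound 2 (0.74 log units; beyond the scatter) and on compound 3 sitting at the limit of > 100000 nM in this assay, at which 2 of the 3 values shown sit. Compound 4 is estimated at 20000 nM in this assay. The expected range for compound 4 runs from 5000 nM to 100000 nM, and a result that is again only a limit remains possible.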

Compound 4, half-maximal inhibitory concentration: 240 nM
For compound 4 the middle estimate is 83-fold (1.92 log units) above the measured one; measured number below the stated range.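

In this assay, amino in place of nitro on an aromatic carbon gives an at least 410-fold lower number from compound 3 to compound 4 (2.61 log units; beyond the scatter), so the change lowers the number on the core of compound 3 as it does on the core of compound 1. Set side by side, the two steps read as follows: the same change on two cores in this assay, an at least 5.5-fold lower number (0.74 log units; beyond the scatter) from compound 1 to compound 2 and an at least 410-fold lower number (2.61 log units; beyond the scatter) from compound 3 to compound 4; the limit leaves it open whether they differ. Compound 1 and compound 3 each stand at a limit of the assay and not a number, so each step gives only a minimum size, and the data show that the direction carries across these two cores but not that the size does: the limit of > 100000 nM in this assay, at which 2 of the 4 values shown sit.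

The compounds shown leave open how far beyond the limit compound 1 and compound 3 truly lie, and whether the same direction would hold on any core other than these two. Also open, as far as these compounds go, is whether a hydroxyl group, an acetamide or a dimethylamino group on the same aromatic carbon would give numbers like those of the amino compounds, or whether the result belongs to amino alone.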